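A Methoxymethyl Swap on a Low-Cytotoxicity Amide

The source may hold more compounds than are shown below. What is called first, only, known or untested is meant among the compounds shown, and "the series" means these compounds.

Compound 2 `COC(=O)c1cccc(C(=O)N2CCCC(C(=O)Nc3ccc(Cl)cc3)C2)c1` stands lowest of the two numbers measured in an ADME assay on PC-3 cells (Homo sapiens) for cytotoxicity, read by WST assay, tested at 100 uM (a higher number here means more inhibition at the concentration tested (going by the name of the read-out), a lower number less inhibition), where compound 2 gives 0%. Compound 1 `O=C(Nc1cccc([N+](=O)[O-])c1)C1CCCN(C(=O)c2cc(C(F)(F)F)cc(C(F)(F)F)c2)C1` gives 9% in this assay, a gap that lies within the usual scatter of this measurement, so neither compound can be called the weaker. Compound 3 `COCc1cccc(C(=O)N2CCCC(C(=O)Nc3ccc(Cl)cc3)C2)c1` differs from compound 2 in one place: methoxymethyl in place of methoxycarbonyl on an aromatic carbon. For the measured compounds named here, no measured pair shows what such a change does here. The step of a number 3 percentage points higher from compound 2 to compound 3 (within the scatter) is therefore expected to be none beyond the scatter. Compound 3 is estimated at 3%, with a range from -8% to 15%.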

Compound 3, a percentage reported as inhibition, at one concentration (the size of the read-out at that concentration, not a potency): 0%
Compound 3: middle estimate off by 3 percentage points, on the high side; low and high end bracket the measured number.
By their numbers in this assay, from the lowest: compounds 2, 3 and 1 (each within the scatter of the next).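

In this assay, methoxymethyl in place of methoxycarbonyl on this aromatic carbon gives no change at the digits printed from compound 2 to compound 3 (within the scatter). For the compounds shown here, this is the first pair differing in one place, and it shows that on this core the reading stays as it was without the carbonyl of the methoxycarbonyl group. Nothing available speaks to the reason for this result. As far as these compounds go, whether an amine or a carboxylic acid on this same carbon would also leave the reading unchanged stays open. So does whether the same swap would give the same result on another core.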